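Aminomethylpyridinyl Analogue Expected to Hold Its Efficacy

The source may hold more compounds than are shown below. What is called first, only, known or untested is meant among the compounds shown, and "the series" means these compounds.

Compound 1 `O=C(O)Cc1sc(C(c2ccc(F)cc2)c2ccc(F)cc2)nc1-c1ccnc(F)c1` and compound 2 `O=C(O)Cc1sc(C(c2ccc(F)cc2)c2ccc(F)cc2)nc1-c1cc(F)cc(F)c1` share one core and differ only in the aromatic group carried on an aromatic carbon of that core. In an in vitro functional assay on HEK285-7 cells for antagonist activity at prostaglandin D2 receptor 2 (Homo sapiens), read by BRET and beta-arrestin recruitment (a lower number here means a smaller maximal response, a higher number a larger maximal response), compound 1 gives 80%, and compound 2 gives 80%. For the measured compounds named here, the step of no change at the digits printed from compound 1 to compound 2 (within the scatter) is the only measured step in the set, and it shows that swapping one six-membered aromatic group for another at this place left the maximal response unmoved. Compound 2 therefore stands level with compound 1 on the numbers shown, and neither can be called the more or the less efficacious.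

Compound 3 `Cc1cc(-c2nc(C(c3ccc(F)cc3)c3ccc(F)cc3)sc2CC(=O)O)cnc1N` has not yet been measured. Its change from compound 2 is 6-amino-5-methylpyridin-3-yl in place of 3,5-difluorophenyl on an aromatic carbon. Going by the values given here, the only measured step that bears on it is no change at the digits printed from compound 1 to compound 2 (within the scatter), which stayed within the scatter for an aromatic swap at the same place, although the group entering compound 3 is of a different kind from either of those already compared. On that basis the step of no change at the digits printed from compound 2 to compound 3 (within the scatter) is expected to be small, with no preferred direction. Compound 3 is estimated to give 80% in this assay, with a likely range from 65% to 95%.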

Compound 3, largest response reached (reported as efficacy), in percent of the reference or control that the assay uses: 80%
The estimate for compound 3 equals the measured number at the digits printed, within the range that was stated.
By their numbers in this assay, from the lowest: compounds 1, 2 and 3 (each within the scatter of the next).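

In this assay, replacing 3,5-difluorophenyl with 6-amino-5-methylpyridin-3-yl gives no change at the digits printed from compound 2 to compound 3 (within the scatter), although the entering group brings 1 hydrogen-bond donor and 2 hydrogen-bond acceptors where the group that leaves has 0 of each. Measured against the other aromatic group, the same group gives no change at the digits printed from compound 1 to compound 3 (within the scatter), so at this place on the five-membered aromatic ring, the three groups shown cannot be told apart by their maximal response, and the earlier comparison of two fluorinated rings could not show that this holds for a ring bearing an amino and a methyl group. Nothing available explains why the maximal response is insensitive to these exchanges.

From the compounds shown here alone, the groups compared here are all six-membered aromatic rings, and the two in the latest step both have 8 heavy atoms, so it remains open whether a saturated piperidine ring, a carboxylic acid or a longer chain ending in an amine at this place would give a different response. The three compounds also share the carboxymethyl group and the bis(4-fluorophenyl)methyl group, so they leave open whether the same indifference would be seen with a different group at either of those places.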